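The source may hold more compounds than are shown below. What is called first, only, known or untested is meant among the compounds shown, and "the series" means these compounds.

In an ADME assay on MCF7 cells (Homo sapiens) for cytotoxicity, read by MTT assay, with a stated time of 48 h (a lower number here means a stronger inhibitor, a higher number a weaker inhibitor), three compounds have been measured. Compound 1 `Fc1ccc2c(Cn3ccnc3)c(-c3ccc(Cl)cc3)[nH]c2c1` gives 45000 nM. Compound 2 `Fc1ccc(-c2[nH]c3cc(Cl)ccc3c2Cn2ccnc2)cc1` gives 41500 nM, and the two values lie within the scatter of each other. The difference between the cores of compound 1 and compound 2 is not broken down here. Compound 3 `COc1ccc(-c2[nH]c3cc(F)ccc3c2Cn2ccnc2)cc1` reports only a limit in this assay, > 1000000 nM. The change from compound 1 to compound 3 is methoxy in place of chloro on an aromatic carbon, and it produced an at least 22-fold higher number from compound 1 to compound 3 (1.34 log units; beyond the scatter), a step that reaches (the limit of > 1000000 nM in this assay, at which 1 of the 3 values shown sits).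

Compound 4 `COc1ccc2c(Cn3ccnc3)c(-c3ccc(F)cc3)[nH]c2c1` is not yet measured. It differs from compound 2 by methoxy in place of chloro on an aromatic carbon. This is the same kind of change as that from compound 1 to compound 3, but the two places differ: in compound 3 the group sits para to a large group on a ring of carbon only, whereas in compound 4 it sits on a ring that is part of a fused system of two rings, meta to a fused ring and para to a fused ring. Resting on the step from compound 1 to compound 3 measured as an at least 22-fold higher number from compound 1 to compound 3 (1.34 log units; beyond the scatter), the step from compound 2 to compound 4 is expected to be a 12-fold higher number from compound 2 to compound 4 (1.08 log units; beyond the scatter), so compound 4 is estimated at 500000 nM, between 100000 nM and 2000000 nM.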

Compound 4, half-maximal inhibitory concentration: > 1000000 nM
Compound 4 ended at the assay's limit; the forecaster's own chance of this, stated with the estimate: 45%; middle value at least 2.0-fold (0.30 log units) away from the limit.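

In this assay, methoxy in place of chloro on an aromatic carbon again gave a large move towards weaker inhibition, an at least 24-fold higher number from compound 2 to compound 4 (1.38 log units; beyond the scatter), although here the group sits on the fused system of two rings and not on the ring of carbon only. So across the two cores shown, the change goes the same way and lies beyond the scatter both times, and the two steps can be set side by side: the same change on two cores in this assay, an at least 22-fold higher number (1.34 log units; beyond the scatter) from compound 1 to compound 3 and an at least 24-fold higher number (1.38 log units; beyond the scatter) from compound 2 to compound 4; the limit leaves it open whether they differ. Among the compounds shown here, the sizes of the steps cannot be compared, so the data do not show that the change carries over by the same amount, only that both steps run into the same ceiling: the limit of > 1000000 nM in this assay, at which 2 of the 4 values shown sit.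

The compounds shown leave open how far the number would move with a group that stays inside the measurable range, such as an amine or a longer chain like ethoxy, in the place of chloro. They also leave open whether the same step would hold on a core in which the imidazole is replaced by another ring, such as a triazole.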